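Removing a tert-Butoxycarbonyl Group from the Sulfonamide Side Chain

The source may hold more compounds than are shown below. What is called first, only, known or untested is meant among the compounds shown, and "the series" means these compounds.

Three measured compounds share one core and differ only in the group on a sulfonyl sulfur. In an ADME assay on microsomes from liver (Homo sapiens) for metabolic stability, with a stated time of 10 min (a lower number here means that less of the compound is left, a higher number that more of the compound is left), compound 1 `O=C(NS(=O)(=O)c1ccccc1)c1ccc(Nc2nc(NC3(c4ccc(Cl)cc4)CC3)nc(OCC(F)(F)F)n2)cc1` gives 100% and compound 3 `O=C(NS(=O)(=O)C1CC1)c1ccc(Nc2nc(NC3(c4ccc(Cl)cc4)CC3)nc(OCC(F)(F)F)n2)cc1` gives 100%. Compound 2 `CC(C)(C)OC(=O)NCCS(=O)(=O)NC(=O)c1ccc(Nc2nc(NC3(c4ccc(Cl)cc4)CC3)nc(OCC(F)(F)F)n2)cc1`, which carries a 2-((tert-butoxycarbonyl)amino)ethyl group there, gives 92%, the lowest of the three numbers, although a number 8 percentage points lower from compound 1 to compound 2 (within the scatter) and a number 8 percentage points higher from compound 2 to compound 3 (within the scatter) both fall within the scatter. Compound 4 `NCCS(=O)(=O)NC(=O)c1ccc(Nc2nc(NC3(c4ccc(Cl)cc4)CC3)nc(OCC(F)(F)F)n2)cc1` is the unmeasured analogue of compound 2 with the following change: hydrogen in place of tert-butoxycarbonyl on an amine nitrogen. For the measured compounds named here, no measured step touches that amine nitrogen; the steps that exist concern only the sulfonyl substituent, and none moved the read-out beyond the scatter. Compound 4 is therefore expected to show no change beyond the scatter, a number 4 percentage points lower from compound 2 to compound 4 (within the scatter) being the estimated step. Compound 4 is estimated at 88%, with a range from 70% to 100%.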

Compound 4, percent of the compound remaining: 100%
Compound 4: middle estimate off by 12 percentage points, on the low side; measured number inside the range.
By their numbers in this assay, from the lowest: compounds 2, 1, 3 and 4 (each within the scatter of the next).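

In this assay, the amine nitrogen of the side chain now has a step of its own: hydrogen in place of tert-butoxycarbonyl gives a number 8 percentage points higher from compound 2 to compound 4 (within the scatter), so removing those 7 heavy atoms leaves the read-out within the scatter. The 2-aminoethyl group also does not separate from cyclopropyl or phenyl on the sulfonyl sulfur, with no change at the digits printed from compound 3 to compound 4 (within the scatter) and no change at the digits printed from compound 1 to compound 4 (within the scatter). No supporting evidence bears on this result. The compounds shown leave open whether a longer chain, a carboxylic acid at the chain end or a dimethylamine in place of the amine would also stay within the scatter.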